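The source may report more compounds than this note shows. Statements on the series, on what has been measured and on what is new or still open speak of the compounds shown alone.

In an assay on membranes from brain for displacement of a labelled ligand from Sigma non-opioid intracellular receptor 1 (Cavia porcellus), read by scintillation counting, with a stated time of 120 min (on this read-out lower numbers stand for stronger inhibition and higher numbers for weaker inhibition), the measured compounds are: compound 1 `COC1Cc2cscc2C2(CCN(Cc3ccccc3)CC2)O1`, 0.22 nM; compound 2 `COC1Cc2c(csc2-c2ccccc2)C2(CCN(Cc3ccccc3)CC2)O1`, 1 nM; compound 3 `COC1Cc2sc(-c3ccccc3)cc2C2(CCN(Cc3ccccc3)CC2)O1`, 5.5 nM.

Compound 2 differs from compound 1 by phenyl in place of hydrogen on an aromatic carbon, giving a 4.5-fold higher number from compound 1 to compound 2 (0.66 log units; beyond the scatter). The difference between the core of compound 1 and the core of compound 3 is not broken down here; compound 3 gives the highest number of the three. Compound 4 `COC1Cc2sc(-c3ccc(-c4ccccc4)cc3)cc2C2(CCN(Cc3ccccc3)CC2)O1` has not yet been measured and differs from compound 3 by phenyl in place of hydrogen on an aromatic carbon. This is the same kind of change as from compound 1 to compound 2, but not the same: there the phenyl enters on an aromatic carbon of a five-membered aromatic ring with 1 sulfur, next to the ring sulfur, whereas here it enters on an aromatic carbon of a six-membered aromatic ring of carbon only, para to a large group. Compound 4 is expected to show a step of a 1.8-fold higher number from compound 3 to compound 4 (0.26 log units; within the scatter), smaller than the earlier 4.5-fold higher number from compound 1 to compound 2 (0.66 log units; beyond the scatter), since that earlier step rests on a different place and compound 3 already stands high. Compound 4 is estimated at 10 nM, between 3 nM and 40 nM.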

Compound 4, inhibition constant: 220 nM
Compound 4: middle estimate off by 22-fold (1.34 log units), on the low side; measured number above the stated range.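

In this assay, phenyl in place of hydrogen on an aromatic carbon gives a 40-fold higher number from compound 3 to compound 4 (1.60 log units; beyond the scatter), so the change moves the number in the same direction on both cores. The size of the step does not carry over from one core to the other: the same change on two cores in this assay, a 4.5-fold higher number (0.66 log units; beyond the scatter) from compound 1 to compound 2 and a 40-fold higher number (1.60 log units; beyond the scatter) from compound 3 to compound 4, 8.8-fold (0.94 log units) apart, beyond the scatter of two such steps This does not show that the core alone sets the size, since the phenyl enters a five-membered aromatic ring with 1 sulfur in one step and a six-membered aromatic ring of carbon only in the other, and two steps give no general rule for the series.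

The compounds shown leave open whether fluorine or a nitrile on that same aromatic carbon would raise the number as far. They also leave open how large the step would be on a third core.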